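Bromo for Nitro on the Aryl Arm of Compound 2

A few compounds are considered here, and "the series" means these few. Any claim that something is new, unique, unknown or untested is made for them only; others in the source may bear on it.

Compound 1 `COc1cc(C2CC(c3cccc4ccccc34)=NN2C(C)=O)ccc1OCc1cn(Cc2ccc([N+](=O)[O-])cc2)nn1` gives 72% in a functional assay on COLO 205 cells (Homo sapiens) for inhibition, read by sulforhodamine B assay, tested at 100 uM; on this read-out lower numbers stand for less inhibition of growth and higher numbers for more inhibition of growth at the one concentration tested.
Compound 2 `COc1cc(C2CC(c3ccc([N+](=O)[O-])cc3)=NN2C(C)=O)ccc1OCc1cn(Cc2ccc([N+](=O)[O-])cc2)nn1` gives 85% in this assay.
Compound 3 `COc1ccc(C2CC(c3ccc(OCc4cn(Cc5ccc([N+](=O)[O-])cc5)nn4)cc3)=NN2C(C)=O)cc1` gives 37% in this assay.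

Compound 2 stands highest of the three measured compounds in this assay. Among the compounds with values here, its nearest neighbour is compound 1, and the one measured step, 4-nitrophenyl in place of naphthalen-1-yl on a carbon with a double bond to nitrogen, reads a number 13 percentage points higher from compound 1 to compound 2 (beyond the scatter), a modest gain beyond the scatter. Compound 3, built on a different arrangement of the same pieces, lies far below both.

Compound 4 `COc1cc(C2CC(c3ccc(Br)cc3)=NN2C(C)=O)ccc1OCc1cn(Cc2ccc([N+](=O)[O-])cc2)nn1` has not yet been tested. It differs from compound 2 only at the aryl arm: bromo in place of nitro on an aromatic carbon. The group that leaves carries two hydrogen-bond acceptors; the group that enters carries none and is a single heavy atom, placed on an aromatic carbon para to a large group.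

Within the data shown here, no measured step exchanges bromo for nitro, so nothing here speaks directly to this change. Among the measured compounds shown here, the only related step, from naphthalen-1-yl to 4-nitrophenyl, was modest, which suggests that this arm shifts the read-out by modest amounts rather than by large ones. Compound 4 is therefore expected to sit somewhat below compound 2, a step of about a number 13 percentage points lower from compound 2 to compound 4 (beyond the scatter), with the estimate for compound 4 at 72%, between 50% and 90%.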

Compound 4, percent growth inhibition at one concentration: 47%
Compound 4: middle estimate off by 25 percentage points, on the high side, and the stated range ends above it.
By their numbers in this assay, from the lowest: compounds 3 and 4 (each within the scatter of the next); then compound 1; then compound 2.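

In this assay, the aryl arm proves able to move the read-out by far more than a modest amount: bromo in place of nitro, on an aromatic carbon para to a large group, reads a number 38 percentage points lower from compound 2 to compound 4 (beyond the scatter) and counts as a large step. The order of the arms also becomes clearer, since 4-bromophenyl in place of naphthalen-1-yl reads a number 25 percentage points lower from compound 1 to compound 4 (beyond the scatter) and so places the 4-bromophenyl compound below both earlier compounds with this arm, making the exchange of a single group on the phenyl ring a larger step than the exchange of the whole aryl arm seen before. No measurement at hand accounts for this difference between nitro and bromo.

Going by these compounds, whether the high number of compound 2 belongs to nitro alone remains open, since an amine, a carboxylic acid or a nitrile on the same aromatic carbon could land near compound 2, near compound 4 or elsewhere. The compounds shown also leave open whether chloro or fluoro would follow bromo, and whether the same ranking of arms would hold at other concentrations.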